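Capping a Hydroxy Group as Methoxy on a Shared Core

A few compounds are considered here, and "the series" means these few. Any claim that something is new, unique, unknown or untested is made for them only; others in the source may bear on it.

Compound 1 `Oc1ccc([C@@H]2C/C(=N\Nc3cnccn3)c3c(O)cc(O)cc3O2)cc1`: in a functional assay on L5178Y cells (Mus musculus) for inhibition, read by MTT assay, with a stated time of 24 h (a higher number here means a weaker inhibitor, a lower number a stronger inhibitor), compound 1 reaches only the limit >= 11300 nM.
Compound 2 `Oc1ccc([C@@H]2C/C(=N\N=C\c3c[nH]c4ccccc34)c3c(O)cc(O)cc3O2)cc1`: in this assay compound 2 reaches only the limit >= 11300 nM.
Compound 3 `O=C(N/N=C1\C[C@@H](c2ccc(O)cc2)Oc2cc(O)cc(O)c21)OCc1ccccc1`: in this assay compound 3 reaches only the limit >= 11300 nM.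

Each of these three values is a limit of the assay rather than a measured number, so none of the three compounds can be ranked against another. Compound 3 thus stands exactly where its two companions stand, at the limit of >= 11300 nM in this assay, at which 3 of the 3 values shown sit. Going by the values given here, the single change between measured compounds, a step that the two limits leave unreadable from compound 1 to compound 3, cannot be read for size: both of its ends are limits.

Compound 4 `COc1cc(O)c2c(c1)O[C@H](c1ccc(O)cc1)C/C2=N\NC(=O)OCc1ccccc1` differs from compound 3 in one place: methyl in place of hydrogen on an oxygen on an aromatic ring. Among the compounds with values here, no measured change of this kind exists among the three compounds, and the one change that is recorded offers no readable size. Within the data shown here, with every value so far sitting at the same limit, the expectation is that compound 4 also yields no number in this assay, and the step is estimated as a step that the limit leaves unreadable from compound 3 to compound 4. For compound 4 the estimated value is 15000 nM, with a likely range from 5000 nM to 60000 nM.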

Compound 4, half-maximal inhibitory concentration: >= 11300 nM
Compound 4 ended at the assay's limit; the forecaster's own chance of this, stated with the estimate: 85%; the middle value is on the limit's open side.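

The change from hydroxy to methoxy between compound 3 and compound 4 gives no readable step, because both ends are limits of the assay and not numbers: the limit of >= 11300 nM in this assay, at which 4 of the 4 values shown sit.

The compounds shown leave open what actual value any of them would reach in this assay, and whether this change moves that value at all.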